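Phenoxy against methoxy in a cytotoxicity series of quinolone esters

This account rests on a few compounds, and the source may have more. Where it says the series, first, only, none or still open, it means among the compounds named here.

Working notes on four ethyl esters of a shared quinolone core. Compound 1 `CCOC(=O)c1c(-c2cccc(OC)c2)[nH]c2cc(OC)c(OC)cc2c1=O` carries a methoxy group on the pendant aryl ring and two methoxy groups on the fused ring. In an ADME assay on BJ cells (Homo sapiens) for cytotoxicity, read by luminescence, with a stated time of 72 h (on this read-out lower numbers stand for an effect already at smaller amounts and higher numbers for an effect only at larger amounts of compound), compound 1 gives > 21500 nM, which is a limit of the assay and not a number. Compound 2 `CCOC(=O)c1c(-c2cccc(Oc3ccccc3)c2)[nH]c2cc(OC)c(OC)cc2c1=O` differs from compound 1 by phenyl in place of methyl on an oxygen on an aromatic ring. In this assay compound 2 gives > 21500 nM, again a limit. The step that the two limits leave unreadable from compound 1 to compound 2 therefore cannot be sized. Compound 3 `CCOC(=O)c1c(-c2cccc(OC)c2)[nH]c2cc(OC)c(Cl)cc2c1=O` differs from compound 1 in its core by chloro in place of methoxy on an aromatic carbon. In this assay compound 3 gives > 21500 nM, also a limit. The step that the two limits leave unreadable from compound 1 to compound 3 is likewise unreadable.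

Compound 4 `CCOC(=O)c1c(-c2cccc(Oc3ccccc3)c2)[nH]c2cc(OC)c(Cl)cc2c1=O` is not yet measured. It differs from compound 3 by phenyl in place of methyl on an oxygen on an aromatic ring. The place of this change reads word for word as it does between compound 1 and compound 2, so it is the same change, made here on the chloro-bearing core rather than on the core of compound 1. The earlier occurrence gave nothing readable, as both ends sat at the limit.

For compound 4 the expectation in this assay is a step that the limit leaves unreadable from compound 3 to compound 4 from compound 3, resting on (the limit of > 21500 nM in this assay, at which 3 of the 3 values shown sit), which leaves no sign of any compound shown reaching a measurable effect. Compound 4 is estimated at 30000 nM, with an expected range from 15000 nM to 80000 nM, and most likely the assay will once more report only a limit.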

Compound 4, half-maximal effective concentration: > 21500 nM
Compound 4 was reported as a limit; the forecaster's own chance of this, stated with the estimate: 85%; the middle value is on the limit's open side.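

In this assay compound 4 gives > 21500 nM, a limit of the assay and not a number. No new step can be read, neither from compound 3 to compound 4 nor from compound 2 to compound 4. The compounds shown leave open whether phenoxy in place of methoxy, or chloro in place of methoxy, changes the read-out at all, and at what concentration any of them would reach a measurable effect: the limit of > 21500 nM in this assay, at which 4 of the 4 values shown sit.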